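Adding a Methyl on the Nitrogen Side Chain

The compounds below may be only part of what the source reports. "The series", "measured", "known", "first", "only" and "open" are said of these compounds alone.

Compound 1 `CCCCC(CCCC)n1ccc2cc(/C(C)=C/C(=O)Nc3ccccc3OCCCC(=O)O)ccc21`: 21 nM
Compound 2 `CCCC(c1ccccc1)n1ccc2cc(/C(C)=C/C(=O)Nc3ccccc3OCCCC(=O)O)ccc21`: 9.1 nM

In an assay on Prostate gland for inhibition of steroid 5-alpha-reductase (Rattus norvegicus) (on this read-out higher numbers stand for weaker inhibition and lower numbers for stronger inhibition), compound 1 gives 21 nM and compound 2 gives 9.1 nM. Compound 2 holds the lower of these two numbers. Compound 3 `C/C(=C\C(=O)Nc1ccccc1OCCCC(=O)O)c1ccc2c(ccn2C(CC(C)C)c2ccccc2)c1` differs from compound 2 by methyl in place of hydrogen on a saturated chain carbon bound to two saturated chain carbons. Among the compounds with values here, the single measured step, a 2.3-fold lower number from compound 1 to compound 2 (0.36 log units; beyond the scatter), exchanges the entire group on the aromatic nitrogen and does not speak to a methyl added on its chain, so no step beyond the scatter is expected in this assay. Compound 3 is therefore estimated at 8 nM, between 3 nM and 25 nM. This corresponds to an expected 1.1-fold lower number from compound 2 to compound 3 (0.06 log units; within the scatter).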

Compound 3, half-maximal inhibitory concentration: 6.3 nM
Beside the measured number, compound 3's estimate is 1.3-fold (0.10 log units) above it; the range from low to high includes it.
By their numbers in this assay, from the lowest: compounds 3 and 2 (each within the scatter of the next); then compound 1.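

In this assay, the change from 1-phenylbutyl to 3-methyl-1-phenylbutyl gives a 1.4-fold lower number from compound 2 to compound 3 (0.16 log units; within the scatter), so this saturated chain carbon carries a methyl with no change that stands clear of the scatter. With 3-methyl-1-phenylbutyl in place of 1-butylpentyl on the aromatic nitrogen, the result is a 3.3-fold lower number from compound 1 to compound 3 (0.52 log units; beyond the scatter), a step beyond the scatter like the one already seen with 1-phenylbutyl. Nothing in the available evidence bears on this result. Still open, on these data alone, is how this chain carbon responds to a group other than methyl, such as a hydroxyl, an amine or a longer chain.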